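A few compounds are considered here, and "the series" means these few. Any claim that something is new, unique, unknown or untested is made for them only; others in the source may bear on it.

In a functional assay on MCF7 cells (Homo sapiens) for antiproliferative activity, read by CellTiter-Glo, with a stated time of 5 days (a higher number here means a weaker inhibitor, a lower number a stronger inhibitor), compound 1 (`CC1=C(c2cccc(O)c2)C(c2ccc(OC[C@H](C)N3CCCC3)cc2)Oc2ccc(O)cc21`) gives 0.2 nM and compound 3 (`CC1=C(c2cccc(O)c2)C(c2ccc(OC[C@H](C)N3CC[C@@H](C)C3)cc2)Oc2ccc(O)cc21`) gives 0.2 nM, together the lowest numbers of the three, while compound 2 (`CC1=C(c2cccc(O)c2)[C@@H](c2ccc(OC[C@H](C)N3CC[C@@H](C)C3)cc2)Oc2ccc(O)cc21`) gives 59 nM. The saturated-ring methyl leaves the number unmoved, no change at the digits printed from compound 1 to compound 3 (within the scatter). The large gap, a 300-fold lower number from compound 2 to compound 3 (2.47 log units; beyond the scatter), goes with the fact that one of compounds 2 and 3 is drawn with a defined configuration and the other without, at the place where they differ. Compound 4 (`CC1=C(c2cccc(C#N)c2)C(c2ccc(OC[C@H](C)N3CC[C@@H](C)C3)cc2)Oc2ccc(O)cc21`) differs elsewhere, with cyano in place of hydroxy on an aromatic carbon. Neither measured step touches this place, so neither sets a size for the change. With compound 3 already at 0.2 nM, a moderate rise is expected in this assay, though one within the scatter remains possible. The expected change is a 5.0-fold higher number from compound 3 to compound 4 (0.70 log units; beyond the scatter). Compound 4 is estimated at 1 nM, within a range of 0.2 nM to 6 nM.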

Compound 4, half-maximal inhibitory concentration: 2.6 nM
Compound 4: the middle estimate sits 2.6-fold (0.41 log units) below what was measured; the measured number falls inside the stated range.
By their numbers in this assay, from the lowest: compounds 1 and 3 (each within the scatter of the next); then compound 4; then compound 2.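

In this assay, the step at this aromatic carbon is a 13-fold higher number from compound 3 to compound 4 (1.11 log units; beyond the scatter), so 3-hydroxyphenyl to 3-cyanophenyl is a large change, beyond the scatter. Within the data shown here, this is the first sign that the number responds to what sits at this place, which the saturated-ring methyl and the drawn configuration could not show. Nothing given here explains the size of this step.

Going by these compounds, whether the step follows the loss of the hydroxy or the arrival of the cyano stays open. A methoxy, a primary amide or plain hydrogen at this carbon would help separate the two.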